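The source may hold more compounds than are shown below. What is called first, only, known or untested is meant among the compounds shown, and "the series" means these compounds.

In a functional assay on HeLa cells (Homo sapiens) for inhibition, read by CCK-8 assay, with a stated time of 4 days (on this read-out higher numbers stand for weaker inhibition and lower numbers for stronger inhibition), compound 1 (`COc1cc(C(=O)O)ccc1NC(=O)[C@@H]1N[C@@H](CC(C)(C)C)[C@](CNCc2ccc(O)cc2)(c2ccc(Cl)cc2F)[C@H]1c1cccc(Cl)c1F`) gives 6560 nM and compound 2 (`COc1cc(C(=O)O)ccc1NC(=O)[C@@H]1N[C@@H](CC(C)(C)C)[C@](C)(c2ccc(Cl)cc2F)[C@H]1c1cccc(Cl)c1F`) gives 10500 nM. Among the compounds with values here, these are the only two numbers available and they lie within the usual scatter of each other, so compound 1 cannot be ranked against its single neighbour. Compound 3 (`COc1cc(C(=O)O)ccc1NC(=O)[C@@H]1N[C@@H](CC(C)(C)C)[C@](CNCc2ccccn2)(c2ccc(Cl)cc2F)[C@H]1c1cccc(Cl)c1F`) keeps the core of compound 1 and differs only at the end of the side chain: pyridin-2-yl in place of 4-hydroxyphenyl on a saturated chain carbon bound to an amine nitrogen. Within the data shown here, no measured compound carries a pyridin-2-yl group, so the data do not test this exchange directly. Among the measured compounds shown here, the nearest evidence is the one measured step, where hydrogen in place of the whole (4-hydroxybenzyl)amino group gave a 1.6-fold higher number from compound 1 to compound 2 (0.20 log units; within the scatter). That step removes more of the side chain than the exchange in compound 3 alters, yet it stays within the scatter. No change beyond the scatter is therefore expected in this assay. The expected size is a 1.1-fold higher number from compound 1 to compound 3 (0.03 log units; within the scatter), with no firm direction. The estimated value for compound 3 is 7000 nM, within an expected range of 3300 nM to 14000 nM.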

Compound 3, half-maximal inhibitory concentration: 9900 nM
The estimate for compound 3 lay 1.4-fold (0.15 log units) below the measured number; measured number inside the range.
By their numbers in this assay, from the lowest: compounds 1, 3 and 2 (each within the scatter of the next).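

In this assay, pyridin-2-yl in place of 4-hydroxyphenyl on a saturated chain carbon bound to an amine nitrogen gave a 1.5-fold higher number from compound 1 to compound 3 (0.18 log units; within the scatter), so this first direct test of the end of the side chain shows no difference that can be told from the scatter, even though the hydroxyl-bearing ring gives way to one with a ring nitrogen. The second new comparison, ((pyridin-2-yl)methyl)amino in place of hydrogen on a saturated chain carbon bound to a saturated ring carbon, gave a 1.1-fold lower number from compound 2 to compound 3 (0.03 log units; within the scatter), so a side chain with this new end, like the (4-hydroxybenzyl)amino chain before it, cannot be told from hydrogen at this place. Nothing at hand bears on these results, and no cause can be given for them.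

The compounds shown leave open whether a dimethylamino group, a piperidine ring or a longer chain in place of ((pyridin-2-yl)methyl)amino would give a number beyond the scatter in this assay. They also leave open whether pyridin-3-yl or a plain phenyl ring at the end of the chain would read any differently from pyridin-2-yl and 4-hydroxyphenyl.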